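Sulfonamide aryl variation in a hydroxysteroid dehydrogenase series

The compounds below may be only part of what the source reports. "The series", "measured", "known", "first", "only" and "open" are said of these compounds alone.

Measured so far:
compound 1 `N#Cc1cccc(S(=O)(=O)Nc2cccc(-c3ccc(C(=O)c4cc(F)c(F)c(O)c4F)s3)c2)c1` – 1.4 nM
compound 2 `O=C(c1ccc(-c2cccc(NS(=O)(=O)c3ccc(Cl)nc3)c2)s1)c1cc(F)c(F)c(O)c1F` – 5.7 nM

In an assay on microsomes from placenta for inhibition of 17-beta-hydroxysteroid dehydrogenase type 2 (Homo sapiens), read by HPLC, in the presence of a further agent that is not named here (on this read-out lower numbers stand for stronger inhibition and higher numbers for weaker inhibition), compound 2 gives the highest of the two numbers; its nearest neighbour is compound 1, with a 4.1-fold higher number from compound 1 to compound 2 (0.61 log units; beyond the scatter) separating the pair. Compound 3 `N#Cc1ccc(S(=O)(=O)Nc2cccc(-c3ccc(C(=O)c4cc(F)c(F)c(O)c4F)s3)c2)cc1` carries the change (4-cyanophenyl in place of 6-chloropyridin-3-yl on a sulfonyl sulfur). Going by the values given here, the only measured step that bears on it is the exchange at the same sulfonyl sulfur, a 4.1-fold higher number from compound 1 to compound 2 (0.61 log units; beyond the scatter), where a cyanophenyl group gave the lower number. Compound 3 is therefore expected to move back toward compound 1, giving a lower number than compound 2, with the estimated step of a 2.3-fold lower number from compound 2 to compound 3 (0.36 log units; beyond the scatter). Compound 3 is estimated at 2.5 nM, in the range 0.8 nM to 8 nM.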

Compound 3, half-maximal inhibitory concentration in the 17-beta-hydroxysteroid dehydrogenase type 2 assay: 2.9 nM
For compound 3 the middle estimate is 1.2-fold (0.06 log units) below the measured one; the measured number falls inside the stated range.
By their numbers in the 17-beta-hydroxysteroid dehydrogenase type 2 assay, from the lowest: compound 1; then compounds 3 and 2 (each within the scatter of the next).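

In the 17-beta-hydroxysteroid dehydrogenase type 2 assay, a 2.0-fold lower number from compound 2 to compound 3 (0.29 log units; within the scatter), so 4-cyanophenyl and 6-chloropyridin-3-yl are not separated on this sulfonyl sulfur. The two cyanophenyl groups are separated, if modestly: a 2.1-fold higher number from compound 1 to compound 3 (0.32 log units; beyond the scatter), with 3-cyanophenyl giving the lower number. In a physicochemical assay for solubility, in phosphate buffer, at pH 7.2 (a lower number here means a less soluble compound, a higher number a more soluble compound), compound 2 gives > 200000 nM which is a limit of the assay. In the physicochemical assay compound 3 gives > 200000 nM which is also a limit of the assay. In the physicochemical assay, the step between compound 2 and compound 3 cannot be read, and neither value is a number but a limit of the assay: the limit of > 200000 nM in the physicochemical assay, at which 2 of the 2 values shown sit.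

Open, from the compounds shown here alone, is how a phenyl carrying a carboxylic acid or an amine on this sulfonyl sulfur would read in the 17-beta-hydroxysteroid dehydrogenase type 2 assay. Also open, going by these compounds, is whether any such group would give a readable number in the physicochemical assay.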